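The compounds below may be only part of what the source reports. "The series", "measured", "known", "first", "only" and "open" are said of these compounds alone.

Of the compounds shown here, three sharing one core have been tested in a functional assay (trachea) for inhibition, with Cavia porcellus as the target; a lower number here means a stronger inhibitor, a higher number a weaker inhibitor. Compound 1 `CC1(C)Oc2ccc(C#N)cc2[C@@H](N2CCC2=O)[C@@H]1O` gives > 20000 nM in this assay, which is a limit and not a number. Compound 2 `CC1(C)Oc2cc(C#N)ccc2[C@@H](N2CCCCC2=O)[C@@H]1O` likewise gives a limit in this assay, > 17000 nM. Compound 3 `CC1(C)C=C(N2CCC2=O)c2cc(C#N)ccc2O1` is the only one of the three to yield a measured value, 7500 nM in this assay. The other two sit at limits, compound 2 at the limit of > 17000 nM in this assay, at which 1 of the 3 values shown sits, and compound 1 at the limit of > 20000 nM in this assay, at which 1 of the 3 values shown sits. Compound 3 thus stands alone as the single number shown, and no step between measured compounds can be drawn from the set. Compound 4 `CC1(C)C=C(N2CCCC2=O)c2cc(C#N)ccc2O1` has not yet been measured. It differs from compound 3 in one place: 2-oxopyrrolidin-1-yl in place of 2-oxoazetidin-1-yl on a double-bonded ring carbon. Among the measured compounds shown here, no measured step of this kind exists among the three compounds, so the expectation rests on compound 3 alone. The change is expected to move compound 4 toward a lower concentration, a step beyond the scatter, though its size is uncertain. Compound 4 is therefore estimated at 2000 nM in this assay, within 500 nM to 8000 nM. The step this estimate implies, a 3.8-fold lower number from compound 3 to compound 4 (0.57 log units; beyond the scatter), is expected rather than measured.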

Compound 4, half-maximal inhibitory concentration: 1570 nM
The estimate for compound 4 lay 1.3-fold (0.11 log units) above the measured number, and the stated range covers the measured number.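

Among the compounds shown here, compound 4 gives the first measured step at this position, the double-bonded ring carbon: in this assay, 2-oxopyrrolidin-1-yl in place of 2-oxoazetidin-1-yl gives a 4.8-fold lower number from compound 3 to compound 4 (0.68 log units; beyond the scatter). The earlier compounds shown here could not show this, as they offered no pair differing in one place. The step shows that, on this core, the five-membered and four-membered rings are not interchangeable at this position, though nothing measured here accounts for the difference.

As far as these compounds go, whether the number would fall further with a simple amine or an open-chain acetylamino group on the double-bonded ring carbon remains open, since two groups on one core cannot set a trend. Equally open, from the compounds shown here alone, is whether a nitro group in place of the nitrile would keep the value of compound 4 in this assay.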